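This account rests on a few compounds, and the source may have more. Where it says the series, first, only, none or still open, it means among the compounds named here.

Three compounds on a shared core frame this account. In a functional assay on MCF7 cells (Homo sapiens) for cytotoxicity, read by MTT assay, with a stated time of 72 h (on this read-out higher numbers stand for weaker inhibition and lower numbers for stronger inhibition), compound 1 `CN(C)c1ccc(CNC(=O)c2nc(Br)c3cccnc3c2N[C@H]2CC[C@H](N)CC2)cc1` gives 5000 nM, while compound 2 `C[C@H](NC(=O)c1nc(Br)c2cccnc2c1N[C@H]1CC[C@H](N)CC1)c1ccc(F)cc1` has "not determined" (no result reported). Compound 3 `COC(=O)c1nc(Br)c2cccnc2c1N[C@H]1CC[C@H](N)CC1` is known only by a limit of the assay, > 20000 nM. Compound 4 `N[C@H]1CC[C@H](Nc2c(C(=O)NCc3cccs3)nc(Br)c3cccnc23)CC1` differs from it as follows: ((thiophen-2-yl)methyl)amino in place of methoxy on a carbonyl carbon. In words, ((thiophen-2-yl)methyl)amino stands in place of methoxy on a carbonyl carbon. Going by the values given here, no step between measured compounds is available, so the expectation leans on a single comparison: compound 4 is an amide, as is compound 1, which gives 5000 nM. A step towards stronger inhibition, beyond the usual scatter, is therefore expected in this assay: an at least 3.3-fold lower number from compound 3 to compound 4 (0.52 log units; beyond the scatter). Compound 4 is estimated at 6000 nM, with an expected range from 2000 nM to 18000 nM.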

Compound 4, half-maximal inhibitory concentration: 7300 nM
Estimate against measurement, compound 4: 1.2-fold (0.09 log units) below; low and high end bracket the measured number.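

In this assay, ((thiophen-2-yl)methyl)amino in place of methoxy on a carbonyl carbon gives an at least 2.7-fold lower number from compound 3 to compound 4 (0.43 log units; beyond the scatter). The size of this step is only a minimum, as compound 3 is known by a limit of the assay: the limit of > 20000 nM in this assay, at which 1 of the 4 values shown sits.

Thiophen-2-yl in place of 4-(dimethylamino)phenyl on a saturated chain carbon bound to an amide-type nitrogen gives a 1.5-fold higher number from compound 1 to compound 4 (0.16 log units; within the scatter), so the two groups are not told apart here. The compounds shown leave open how a carboxylic acid or a simple methylamino group on this carbonyl carbon would read out.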